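Swapping the benzyl ring substituent in a spleen antagonist series

The source may report more compounds than this note shows. Statements on the series, on what has been measured and on what is new or still open speak of the compounds shown alone.

Compound 1 `COc1cccc(OC)c1OCCNCCOc1ccccc1OCc1ccc(Cl)cc1`: 8.06
Compound 2 `COc1cccc(OC)c1OCCNCCOc1ccccc1OCc1ccc([N+](=O)[O-])cc1`: 9.02

Compound 1 stands lowest of the two numbers in a functional assay on spleen for antagonist activity at Alpha-1B adrenergic receptor (Rattus norvegicus); on this read-out lower numbers stand for lower potency and higher numbers for higher potency (the scale is a negative logarithm); compound 2 lies above it by a number 0.96 log units higher from compound 1 to compound 2 (beyond the scatter). Compound 3 `COc1ccccc1COc1ccccc1OCCNCCOc1c(OC)cccc1OC` differs from compound 1 by 2-methoxyphenyl in place of 4-chlorophenyl on a saturated chain carbon bound to an oxygen on an aromatic ring. Within the data shown here, the single measured step concerns nitro in place of chloro and does not address exchanging the whole 4-chlorophenyl for 2-methoxyphenyl, so no measured step bears directly on this change. With nothing to anchor a direction, the step is expected to lie within the scatter: a number 0.06 log units lower from compound 1 to compound 3 (within the scatter). Compound 3 is therefore estimated at 8, with a range from 7.3 to 8.7.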

Compound 3, negative logarithm of the antagonist equilibrium constant: 8.13
The estimate for compound 3 lay 0.13 log units below the measured number; the range from low to high includes it.
By their numbers in this assay, from the lowest: compounds 1 and 3 (each within the scatter of the next); then compound 2.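

Exchanging 4-chlorophenyl for 2-methoxyphenyl leaves the two compounds indistinguishable in this assay (a number 0.07 log units higher from compound 1 to compound 3 (within the scatter)). The earlier nitro-for-chloro step changed only the group on the ring, whereas this exchange alters both the group and its printed ring number. Compound 2 with 4-nitrophenyl still stands apart from compound 3 (a number 0.89 log units lower from compound 2 to compound 3 (beyond the scatter)), and no supporting data explain either result. As far as these compounds go, since the group and its ring number change together here, their separate contributions remain open. 4-Methoxyphenyl and 2-chlorophenyl would separate them, while an amine on the ring remains an open case.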